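This account rests on a few compounds, and the source may have more. Where it says the series, first, only, none or still open, it means among the compounds named here.

Two spiro compounds built on a shared core have been tested in a functional assay on MCF7 cells (Homo sapiens) for antiproliferative activity, read by MTT assay, with a stated time of 48 h; a lower number here means a stronger inhibitor, a higher number a weaker inhibitor. Compound 1 `N#CC1=C(N)Oc2c(c3nc4ccccc4nc3c3ccccc23)C12C(=O)N(Cc1cnnn1-c1ccc(Cl)c(Cl)c1)c1ccccc12` reaches only the limit of the assay, > 50000 nM. For the measured compounds named here, compound 2 `N#CC1=C(N)Oc2c(N)cc3nc4ccccc4nc3c2C12C(=O)N(Cc1cnnn1-c1ccccc1Br)c1ccccc12` gives 30700 nM, the only actual number obtained so far. The result for compound 1 is a limit (the limit of > 50000 nM in this assay, at which 1 of the 2 values shown sits). Compound 3 `CCc1cccc(C)c1-n1nncc1CN1C(=O)C2(C(C#N)=C(N)Oc3c(N)cc4nc5ccccc5nc4c32)c2ccccc21` differs from compound 2 in one place (2-ethyl-6-methylphenyl in place of 2-bromophenyl on an aromatic nitrogen). Going by the values given here, with no measured step between related compounds to lean on, the step from compound 2 to compound 3 is expected to stay within the scatter, which a 1.0-fold lower number from compound 2 to compound 3 (0.01 log units; within the scatter) reflects. Compound 3 is therefore estimated at 30000 nM, within 10000 nM to 100000 nM.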

Compound 3, half-maximal inhibitory concentration: > 50000 nM
Compound 3: only a limit was reported (the forecaster's own chance of this, stated with the estimate: 35%); middle value at least 1.6-fold (0.22 log units) away from the limit.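

At this position, 2-ethyl-6-methylphenyl in place of 2-bromophenyl gives an at least 1.6-fold higher number from compound 2 to compound 3 (0.21 log units; that floor lies within the scatter), so this change brings no stronger inhibition. In this assay compound 3 gives > 50000 nM, which is a limit and not a number. Compound 3 therefore adds a second compound without an actual number: the limit of > 50000 nM in this assay, at which 2 of the 3 values shown sit.

On these data alone, whether a phenyl ring carrying an amine or a carboxylic acid would give a lower number at this position stays open. As far as these compounds go, the true size of the step also remains unknown.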